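The compounds below may be only part of what the source reports. "The series", "measured", "known", "first", "only" and "open" are said of these compounds alone.

In a functional assay on HL-60 cells (Homo sapiens) for cytotoxicity, read by luminescence and CellTiter-Glo, with a stated time of 3 days (on this read-out higher numbers stand for weaker inhibition and lower numbers for stronger inhibition), compound 1 `N#Cc1ccc(NC(=O)c2ccc(C(F)(F)F)cc2O)cc1` gives 1030 nM, compound 2 `N#Cc1ccc(NC(=O)c2cc(Cc3ccccc3)ccc2O)cc1` gives 1740 nM and compound 3 `COc1ccc(C(=O)Nc2ccc(C#N)cc2)c(O)c1` gives 5470 nM, the highest of the three numbers. Compound 4 `N#Cc1ccc(NC(=O)c2ccccc2O)cc1` has not yet been measured, and it differs from compound 3 by this change: hydrogen in place of methoxy on an aromatic carbon. Hydrogen has not yet been measured at this carbon. Among the measured compounds shown here, the one measured step at the same carbon is modest and beyond the scatter: a 5.3-fold higher number from compound 1 to compound 3 (0.73 log units; beyond the scatter), with methoxy in place of trifluoromethyl. Taking that step as the guide, a smaller move toward a lower number is expected, possibly not beyond the scatter: a 1.8-fold lower number from compound 3 to compound 4 (0.26 log units; within the scatter). For compound 4 the estimated value is 3000 nM, with an expected range from 1000 nM to 8000 nM.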

Compound 4, half-maximal inhibitory concentration: 4620 nM
Estimate against measurement, compound 4: 1.5-fold (0.19 log units) below, within the range that was stated.
By their numbers in this assay, from the lowest: compounds 1 and 2 (each within the scatter of the next); then compounds 4 and 3 (each within the scatter of the next).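

In this assay, taking away the methoxy group barely registers: a 1.2-fold lower number from compound 3 to compound 4 (0.07 log units; within the scatter), so at this carbon methoxy and hydrogen cannot be told apart. Trifluoromethyl does separate from hydrogen, with a 4.5-fold higher number from compound 1 to compound 4 (0.65 log units; beyond the scatter), and so does benzyl, with a 2.7-fold higher number from compound 2 to compound 4 (0.42 log units; beyond the scatter). Among these four compounds, then, the unsubstituted ring sits with the methoxy compound, and both give higher numbers than the trifluoromethyl and benzyl compounds.

Nothing available explains these differences. From the compounds shown here alone, how an amine or a carboxylic acid on this carbon would compare remains open.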